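A 3-Nitrophenyl Ester Joins Two Measured Esters

The source may report more compounds than this note shows. Statements on the series, on what has been measured and on what is new or still open speak of the compounds shown alone.

Within the data shown here, in a functional assay on MCF7 cells (Homo sapiens) for cytotoxicity, read by colony formation (on this read-out higher numbers stand for weaker inhibition and lower numbers for stronger inhibition), compound 2 `COC(=O)C1=CO[C@@H](O[C@@H]2O[C@H](COC(=O)C=C(C)C)[C@@H](OC(C)=O)[C@H](OC(C)=O)[C@H]2OC(C)=O)[C@@H]2[C@@H](C)[C@@H](OC(C)=O)C[C@H]12` gives 4.65 ug/mL, the higher of the two numbers so far, while compound 1 `CCCCCCCCCCCC(=O)OC[C@H]1O[C@@H](O[C@@H]2OC=C(C(=O)OC)[C@H]3C[C@H](OC(C)=O)[C@H](C)[C@@H]23)[C@H](OC(C)=O)[C@@H](OC(C)=O)[C@@H]1OC(C)=O` gives 0.75 ug/mL. Compound 3 `COC(=O)C1=CO[C@@H](O[C@@H]2O[C@H](COC(=O)c3cccc([N+](=O)[O-])c3)[C@@H](OC(C)=O)[C@H](OC(C)=O)[C@H]2OC(C)=O)[C@@H]2[C@@H](C)[C@@H](OC(C)=O)C[C@H]12` carries 3-nitrophenyl in place of 2-methylprop-1-en-1-yl on a carbonyl carbon. Among the measured compounds shown here, the only measured step at this place is a 6.2-fold higher number from compound 1 to compound 2 (0.79 log units; beyond the scatter), modest but beyond the scatter. It shows that this place can move the number, but neither group in it has an aromatic ring, so it indicates no direction for the new group. No step beyond the scatter is therefore expected. The expected step is a 1.4-fold lower number from compound 2 to compound 3 (0.15 log units; within the scatter). For compound 3 the estimate is 3.3 ug/mL, with an expected range from 1 ug/mL to 10 ug/mL.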

Compound 3, half-maximal inhibitory concentration: 3.42 ug/mL
Compound 3: the middle estimate sits 1.0-fold (0.02 log units) below what was measured; the range from low to high includes it.
By their numbers in this assay, from the lowest: compound 1; then compounds 3 and 2 (each within the scatter of the next).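

In this assay, putting an aromatic ring on this carbonyl carbon, as 3-nitrophenyl in place of 2-methylprop-1-en-1-yl, leaves the number within the scatter (a 1.4-fold lower number from compound 2 to compound 3 (0.13 log units; within the scatter)). The same group in place of undecyl gives a step beyond the scatter (a 4.6-fold higher number from compound 1 to compound 3 (0.66 log units; beyond the scatter)), so among these three esters compound 1 alone stands apart. Nothing available here explains this difference.

As far as these compounds go, whether a plain phenyl ester would stay level with compound 3 remains open. So does whether a chain longer than undecyl would lower the number further.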